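The source may report more compounds than this note shows. Statements on the series, on what has been measured and on what is new or still open speak of the compounds shown alone.

Measured in an ADME assay on MT4 cells (Homo sapiens) for cytotoxicity; a lower number here means that less compound is tolerated, a higher number that more compound is tolerated:
Compound 1 `CCOC(=O)c1ccc(NC(=O)CSc2snnc2-c2ccc(Cl)cc2Cl)c(Br)c1`: > 228000 nM, a limit
Compound 2 `Cc1ccc(NC(=O)CSc2snnc2-c2ccc(Cl)cc2Cl)c(Br)c1`: > 255000 nM, a limit

Compound 1 has no exact reading in this assay. Its only entry is the limit > 228000 nM. Compound 2 likewise has only a limit, > 255000 nM.

The next compound to be tested is compound 3 `CCOC(=O)c1ccc(NC(=O)CSc2snnc2-c2ccc(OC)cc2)c(Br)c1`, which keeps the rest of compound 1 but carries 4-methoxyphenyl in place of 2,4-dichlorophenyl on an aromatic carbon. The enlisted change brings in one hydrogen-bond acceptor and leaves the heavy-atom count unchanged.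

Going by the values given here, only one measured step bears on this question, a step that the two limits leave unreadable from compound 1 to compound 2. It has no readable size, and it concerns methyl in place of ethoxycarbonyl rather than the group changed here. The data therefore give no size to carry over, and no step beyond the scatter is expected, in either direction. Compound 3 may well return a limit too.

The expected change is an at least 1.1-fold lower number from compound 1 to compound 3 (0.05 log units; that floor lies within the scatter).

Compound 3 is estimated at 200000 nM, with an expected range of 60000 nM to 260000 nM.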

Compound 3, half-maximal cytotoxic concentration: > 245000 nM
Compound 3 ended at the assay's limit (the forecaster's own chance of this, stated with the estimate: 65%); middle value at least 1.2-fold (0.08 log units) from the limit.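

In this assay compound 3 gave > 245000 nM, which is a limit. Going by these compounds alone, compound 1 also has only a limit, so no step from compound 1 to compound 3 can be read. The compounds shown leave open where the exact reading of any of them lies, and whether 4-methoxyphenyl in place of 2,4-dichlorophenyl shifts it at all.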